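The source may report more compounds than this note shows. Statements on the series, on what has been measured and on what is new or still open speak of the compounds shown alone.

Three compounds have so far been measured in a functional assay on PANC-1 cells (Homo sapiens) for inhibition, read by MTT assay, with a stated time of 24 h, tested at 10 uM; a lower number here means less inhibition, a higher number more inhibition at the concentration tested (going by the name of the read-out):

Compound 1, `CC(C)=CCC/C(C)=C/CC1Cc2c(OCCCNC(=O)c3ccco3)cc(=O)n(CCCO)c2CC1(C)C`: 2.8%
Compound 2, `COc1cccc(NC(=O)Oc2cc(=O)n(CCCO)c3c2CC(C/C=C(\C)CCC=C(C)C)C(C)(C)C3)c1`: 11.3%
Compound 3, `CC(C)=CCC/C(C)=C/CC1Cc2c(OC(=O)Nc3cccc(F)c3)cc(=O)n(CCCO)c2CC1(C)C`: 0%

Compound 3 has the lowest of the three numbers. Its nearest neighbour is compound 1, the gap being a number 2.8 percentage points lower from compound 1 to compound 3 (within the scatter). The furthest is compound 2, the gap being a number 11.3 percentage points lower from compound 2 to compound 3 (beyond the scatter). The unmeasured compound 4, `CC(C)=CCC/C(C)=C/CC1Cc2c(OC(=O)Nc3ccc(Cl)cc3)cc(=O)n(CCCO)c2CC1(C)C`, differs from compound 3 in one place: 4-chlorophenyl in place of 3-fluorophenyl on an amide-type nitrogen.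

Within the data shown here, of the measured steps, the one from compound 2 to compound 3 bears most directly on this change, since it too exchanges one substituent on the phenyl of the carbamate for another; its size was a number 11.3 percentage points lower from compound 2 to compound 3 (beyond the scatter), a modest step. The steps of a number 8.5 percentage points higher from compound 1 to compound 2 (within the scatter) and a number 2.8 percentage points lower from compound 1 to compound 3 (within the scatter) replace the whole group on the ring oxygen and are both within the scatter, so they give less guidance. Among the measured compounds shown here, since compound 3 sits at the floor of the read-out, any movement for compound 4 can only be upward, and the single halogen-for-halogen exchange is expected to give at most a small shift, likely within the scatter: compound 4 is expected at 5%, between 0% and 18%, which amounts to an estimated step of a number 5 percentage points higher from compound 3 to compound 4 (within the scatter).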

Compound 4, a percentage reported as inhibition, at one concentration (the size of the read-out at that concentration, not a potency): 4.3%
Compound 4: the middle estimate sits 0.7 percentage points above what was measured, and the stated range covers the measured number.
By their numbers in this assay, from the lowest: compounds 3, 1, 4 and 2 (each within the scatter of the next, the first and the last beyond it).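

In this assay, putting 4-chlorophenyl in place of 3-fluorophenyl on the amide-type nitrogen gives a number 4.3 percentage points higher from compound 3 to compound 4 (within the scatter) even though the halogen and its place on the ring change together, so this double change does not separate the two carbamates. Among these compounds, the same holds for 4-chlorophenyl in place of 3-methoxyphenyl at this nitrogen, which gives a number 7 percentage points lower from compound 2 to compound 4 (within the scatter) and so contrasts with the fluoro-for-methoxy exchange, the one step here beyond the scatter, which gave a number 11.3 percentage points lower from compound 2 to compound 3 (beyond the scatter) in the same assay. The larger exchange on the ring oxygen, from the furan amide chain to the (4-chlorophenyl)carbamoyl group, gives a number 1.5 percentage points higher from compound 1 to compound 4 (within the scatter) and likewise leaves the number within the scatter, and no measurement at hand explains any of these numbers.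

As far as these compounds go, whether the halogen itself or its place on the ring matters stays open, since the two vary together in this pair. Also open, from the compounds shown here alone, is whether an amine or a carboxylic acid on this phenyl ring, or a longer chain between the ring and the amide-type nitrogen, would raise the inhibition clearly above the values seen so far.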